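The compounds below may be only part of what the source reports. "The series", "measured", "known", "first", "only" and "open" are said of these compounds alone.

Working notes on the series, which shares one core and varies the group on the sulfonyl sulfur. In a functional assay on DLD-1 cells (Homo sapiens) for antiproliferative activity, read by CellTiter-Glo, with a stated time of 72 h (a higher number here means a weaker inhibitor, a lower number a stronger inhibitor), compound 2 `CC1CCN(C2CCN(S(=O)(=O)c3ccc(C#N)cc3)CC2)CC1` gives 2800 nM. Compound 1 `CC1CCN(C2CCN(S(=O)(=O)c3cccnc3Cl)CC2)CC1` reads > 5000 nM, which is a limit of the assay. Compound 3 `CC1CCN(C2CCN(S(=O)(=O)c3cncc(Br)c3)CC2)CC1` reads > 5000 nM, also a limit and not a number. Compound 3 therefore stands at the limit of > 5000 nM in this assay, at which 2 of the 3 values shown sit.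

Compound 4 `CC1CCN(C2CCN(S(=O)(=O)c3cc(Cl)cc(Cl)c3)CC2)CC1` differs from it by 3,5-dichlorophenyl in place of 5-bromopyridin-3-yl on a sulfonyl sulfur.

Within the data shown here, two measured steps bear on this change: an at least 1.7-fold lower number from compound 1 to compound 2 (0.25 log units; that floor lies within the scatter), and an at least 1.7-fold higher number from compound 2 to compound 3 (0.25 log units; that floor lies within the scatter). Among the three measured compounds, only compound 2 gives a number, and its ring is of carbon only, as in compound 4. Compound 1 and compound 3 both carry a ring with a hetero atom, but three compounds support no firm pattern. A modest move towards a lower number is expected, possibly no larger than the scatter, and a further limit remains quite possible. The expected step is an at least 1.4-fold lower number from compound 3 to compound 4 (0.15 log units; that floor lies within the scatter). The reference point for this expectation is compound 2 at 2800 nM. For compound 4 the estimate is 3500 nM, with an expected range of 1500 nM to 8000 nM.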

Compound 4, half-maximal inhibitory concentration: 3400 nM
For compound 4 the middle estimate is 1.0-fold (0.01 log units) above the measured one, and the stated range covers the measured number.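

In this assay, compound 4 is the second compound of the series to give a number and not a limit, and its ring, like that of compound 2, is of carbon only. The reading between these two is a 1.2-fold higher number from compound 2 to compound 4 (0.08 log units; within the scatter), so 3,5-dichlorophenyl and 4-cyanophenyl on the sulfonyl sulfur cannot be told apart here, and the readings an at least 1.4-fold lower number from compound 3 to compound 4 (0.16 log units; that floor lies within the scatter) and an at least 1.4-fold lower number from compound 1 to compound 4 (0.16 log units; that floor lies within the scatter) are floors that establish no separation from the two groups with a hetero atom in the ring. Across the four compounds, numbers go with the carbon-only rings and limits with the rings holding a hetero atom, with no compound against this split, yet the split rests on few compounds and the limits are not numbers: the limit of > 5000 nM in this assay, at which 2 of the 4 values shown sit.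

The compounds shown leave open whether the hetero atom in the ring matters at all, since the halogens on the ring change along with it, and how far the true values of compound 1 and compound 3 lie from compound 4. They also leave open what an amine or a carboxylic acid on the ring would do at this position.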